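Amide variation on a shared core: an expected result

The source may report more compounds than this note shows. Statements on the series, on what has been measured and on what is new or still open speak of the compounds shown alone.

Compound 1 `O=C(c1cccc(Nc2ncc(F)c(Nc3ccc(F)cc3)n2)c1)N1CCCCC1`: 13800 nM
Compound 2 `O=C(NCCO)c1cccc(Nc2ncc(F)c(Nc3ccc(F)cc3)n2)c1`: 21400 nM
Compound 3 `CN(C)CC(=O)Nc1cccc(Nc2ncc(F)c(Nc3ccc(F)cc3)n2)c1`: 1810 nM

Three compounds share a core and differ only in the group carried on one aromatic carbon. In a functional assay on KBVIN cells (Homo sapiens) for antiproliferative activity, read by sulforhodamine B assay, with a stated time of 3 days (a lower number here means a stronger inhibitor of growth, a higher number a weaker inhibitor of growth), compound 1 gives 13800 nM, the second highest of the three numbers; compound 2 gives 21400 nM, and compound 3 gives 1810 nM.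

The step of a 1.6-fold higher number from compound 1 to compound 2 (0.19 log units; within the scatter) exchanges one amide partner for another on the carbonyl carbon and stays within the scatter. The steps of a 7.6-fold lower number from compound 1 to compound 3 (0.88 log units; beyond the scatter) and a 12-fold lower number from compound 2 to compound 3 (1.07 log units; beyond the scatter) change the whole group on the aromatic carbon and are larger, but they do not bear on a change confined to the carbonyl carbon.

Compound 4 `O=C(Nc1ccccn1)c1cccc(Nc2ncc(F)c(Nc3ccc(F)cc3)n2)c1` differs from compound 1 in exactly that way: (pyridin-2-yl)amino in place of piperidin-1-yl on a carbonyl carbon. Among the compounds with values here, the only step of the same kind, from compound 1 to compound 2, stayed within the scatter, so in this assay no step beyond the scatter is expected here, and compound 4 is estimated at 12000 nM, between 4000 nM and 40000 nM. The expected step is a 1.2-fold lower number from compound 1 to compound 4 (0.06 log units; within the scatter).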

Compound 4, concentration for 50% growth inhibition: 13700 nM
The estimate for compound 4 lay 1.1-fold (0.06 log units) below the measured number; the range from low to high includes it.
By their numbers in this assay, from the lowest: compound 3; then compounds 4, 1 and 2 (each within the scatter of the next).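

In this assay, the change from a non-aromatic ring on the carbonyl carbon to an aromatic one, with a hydrogen-bond donor and acceptor counted where piperidin-1-yl has none, gives a 1.0-fold lower number from compound 1 to compound 4 (0.00 log units; within the scatter). Pyridin-2-yl in place of 2-hydroxyethyl on the amide-type nitrogen gives a 1.6-fold lower number from compound 2 to compound 4 (0.19 log units; within the scatter), so all three amide partners on this carbonyl carbon now lie within the scatter of one another. The step of a 7.6-fold higher number from compound 3 to compound 4 (0.88 log units; beyond the scatter) replaces the whole group on the aromatic carbon, and compound 4 stands as far from compound 3 as compound 1 does.

Nothing given here accounts for how little these amide partners alter the number or for what sets compound 3 apart. Going by these compounds, whether a partner on the carbonyl carbon carrying a dimethylamino group or a carboxylic acid would give a step beyond the scatter remains open.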